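The source may hold more compounds than are shown below. What is called first, only, known or untested is meant among the compounds shown, and "the series" means these compounds.

Measured so far:
compound 1 `Cc1nc(S(C)(=O)=O)ccc1Oc1ncnc(OC2CCN(C(=O)OC(C)(C)C(F)(F)F)CC2)c1F` gives 6.53 nM in a functional assay on isolated protein for inhibition of Glucose-dependent insulinotropic receptor (Homo sapiens), read by HTRF and cAMP accumulation; a higher number here means that more compound is needed for the effect, a lower number that less compound is needed
compound 2 `Cc1nc(S(C)(=O)=O)ccc1Oc1ncnc(OC2CCN(C(=O)O[C@@H](C)C(F)(F)F)CC2)c1F` gives 9.86 nM in this assay

Compound 2 stands at the higher of the two numbers, but the step of a 1.5-fold higher number from compound 1 to compound 2 (0.18 log units; within the scatter) is within the scatter, so nothing separates the pair. Compound 3 `Cc1nc(S(C)(=O)=O)ccc1Oc1ncnc(OC2CCN(C(=O)OC3(C(F)(F)F)CCC3)CC2)c1F` differs from compound 2 by 1-(trifluoromethyl)cyclobutyl in place of 1-(trifluoromethyl)ethyl on an oxygen next to a carbonyl group. For the measured compounds named here, only one measured step bears on this position, the exchange of 1-methyl-1-(trifluoromethyl)ethyl for 1-(trifluoromethyl)ethyl, and it moved the number little. Compound 3 carries a group on that oxygen that is again fully substituted at the carbon bearing trifluoromethyl, as in compound 1, so no step beyond the scatter is expected in this assay; the estimated step is a 1.3-fold lower number from compound 2 to compound 3 (0.12 log units; within the scatter). Compound 3 is therefore expected to give about 7.5 nM, with a range of 3 nM to 19 nM.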

Compound 3, half-maximal effective concentration: 14.3 nM
The estimate for compound 3 lay 1.9-fold (0.28 log units) below the measured number, within the range that was stated.
By their numbers in this assay, from the lowest: compounds 1, 2 and 3 (each within the scatter of the next, the first and the last beyond it).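

In this assay, 1-(trifluoromethyl)cyclobutyl in place of 1-(trifluoromethyl)ethyl on an oxygen next to a carbonyl group gave a 1.5-fold higher number from compound 2 to compound 3 (0.16 log units; within the scatter), so this exchange does not separate the pair. For the compounds shown here, in place of 1-methyl-1-(trifluoromethyl)ethyl, the same group gave a 2.2-fold higher number from compound 1 to compound 3 (0.34 log units; beyond the scatter), the first step at this position to pass the scatter, though only a modest one, which shows that full substitution at the carbon bearing trifluoromethyl does not alone keep a compound within the scatter of compound 1. Nothing available explains this difference between the two fully substituted groups.

The compounds shown leave open whether this position needs trifluoromethyl at all, as a tert-butyl or an unsubstituted cyclobutyl group would test. They also leave open how a larger ring, such as 1-(trifluoromethyl)cyclopentyl, would read in this assay.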